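Moving the chlorines of compound 1

This account rests on a few compounds, and the source may have more. Where it says the series, first, only, none or still open, it means among the compounds named here.

Measured so far in an ADME assay on U-937 cells (Homo sapiens) for cytotoxicity, read by MTT assay, with a stated time of 24 h (a lower number here means that less compound is tolerated, a higher number that more compound is tolerated), are two compounds:
- compound 1 `Clc1ccc(C(CCn2ccnc2)Oc2ccc(Cl)cc2Cl)cc1` gives 172000 nM
- compound 2 `Cc1ccc(OC(CCn2ccnc2)c2ccccc2)cc1` gives 141000 nM

Compound 1 sits level with compound 2: their two values lie within the usual scatter of repeated measurements, so neither can be ranked above the other. Among the compounds with values here, no two measured compounds differ in one place only, so the data offer no direct guide to the size of a single change.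

Compound 3 `Clc1ccc(C(CCn2ccnc2)Oc2cc(Cl)cc(Cl)c2)cc1` has the same atoms as compound 1, joined differently: 3,5-dichlorophenyl in place of 2,4-dichlorophenyl on an oxygen on a saturated carbon. The shared core stays untouched.

Compound 1 differs from compound 2 in more than one place, yet compound 2 still gives 141000 nM and stays within the scatter of compound 1. On that slim evidence, no change beyond the scatter is expected in this assay in either direction. The expected move is small, a 1.1-fold lower number from compound 1 to compound 3 (0.06 log units; within the scatter), and could easily go the other way. For compound 3 the estimated value is 150000 nM (range 70000 nM to 320000 nM).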

Compound 3, half-maximal cytotoxic concentration: 180000 nM
The estimate for compound 3 lay 1.2-fold (0.08 log units) below the measured number; the range from low to high includes it.
By their numbers in this assay, from the lowest: compounds 2, 1 and 3 (each within the scatter of the next).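

Within the data shown here, replacing 2,4-dichlorophenyl with 3,5-dichlorophenyl on an oxygen on a saturated carbon is the first change that can be read in one place alone. In this assay this swap gives a small step (a 1.0-fold higher number from compound 1 to compound 3 (0.02 log units; within the scatter)) that cannot be told apart from repeat-to-repeat variation, so compound 1 and compound 3 stand level. At this position, then, these two arrangements of the same two chlorines make no readable difference to how much compound the cells tolerate, and nothing available explains that result.

This single pair covers only two dichlorophenyl patterns, so it cannot show whether the position would stay equally insensitive to a very different group on the ring, such as a carboxylic acid or an amine. It also leaves open whether replacing the chlorines with methoxy groups, or lengthening the saturated chain that links the oxygen-bearing carbon to the imidazole, would produce a step clearly larger than the usual scatter.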